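Methoxy to dimethylamino: expected shift in ear inhibition

This account rests on a few compounds, and the source may have more. Where it says the series, first, only, none or still open, it means among the compounds named here.

Of the compounds shown here, two of the shared core have numbers so far. Compound 1 `O=C(/C=C/c1ccc(Cl)cc1Cl)c1ccc(O)cc1O` in a functional assay on the whole organism (Ear, strain Kunming) for inhibition, with Mus musculus as the target, with a stated time of 2 h, at a dose of 200 mg/kg by the oral route (a higher number here means more inhibition at the dose given (going by the name of the read-out), a lower number less inhibition), gives 26%. Compound 2 `COc1ccc(/C=C/C(=O)c2ccc(O)cc2O)cc1` in this assay gives 51.4%. Compound 2 stands highest of the two numbers; its nearest neighbour is compound 1, whose number is lower by a gap beyond the usual scatter. Among the compounds with values here, the two measured compounds differ in more than one place, so no single-point step between them can be drawn from the data.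

Compound 3 `CN(C)c1ccc(/C=C/C(=O)c2ccc(O)cc2O)cc1` differs from compound 2 in one place: dimethylamino in place of methoxy on an aromatic carbon. Nothing measured in the series bears directly on this exchange, so the expectation rests on compound 2 alone. The step in this assay is expected to be small, most likely within the scatter, with a slight lean upward rather than downward; the expected step is a number 3.6 percentage points higher from compound 2 to compound 3 (within the scatter). For compound 3 the estimated value in this assay is 55%, with an expected range from 35% to 75%.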

Compound 3, a percentage reported as inhibition, in the whole organism at one dose (the size of the read-out at that dose, not a potency): 62.6%
Compound 3: middle estimate off by 7.6 percentage points, on the low side; the range from low to high includes it.
By their numbers in this assay, from the lowest: compound 1; then compound 2; then compound 3.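

Within the data shown here, this is the first step that can be read at a single point: in this assay, dimethylamino in place of methoxy on an aromatic carbon, para to a large group, gives a number 11.2 percentage points higher from compound 2 to compound 3 (beyond the scatter). The position therefore accepts an exchange that adds to the heavy-atom count, with the counts of hydrogen-bond donors and acceptors and the net charge unchanged, and the number in this whole-organism read-out rises rather than falls. No measured property of either group is available to account for the step, so the change can be recorded but not explained.

From the compounds shown here alone, whether the rise follows the nitrogen or the two methyl groups stays open: a primary amine, a methylamino group or a ring amine such as morpholine at this position would separate the two, and a carboxylic acid would test a very different group at the same place. All of these numbers are read at one dose, so the step describes the size of the inhibition at that dose and leaves the relative potency of compound 2 and compound 3 open.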